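The source may hold more compounds than are shown below. What is called first, only, known or untested is meant among the compounds shown, and "the series" means these compounds.

Compound 1 `COc1ccc(Cn2c(CCc3c[nH]c4ccccc34)nnc2[C@H](NC(=O)Cc2ccncc2)c2c[nH]c3ccccc23)cc1` gives 76 nM in an in vitro assay on LLC-PK1 cells for displacement of a labelled ligand from growth hormone secretagogue receptor type 1 (Homo sapiens); a lower number here means a stronger inhibitor, a higher number a weaker inhibitor. Compound 2 `COc1ccc(Cn2c(CCc3ccccc3)nnc2[C@H](NC(=O)Cc2ccncc2)c2c[nH]c3ccccc23)cc1` carries phenyl in place of 1H-indol-3-yl on a saturated chain carbon, two bonds along the chain from an aromatic carbon; in this assay compound 2 gives 270 nM, and the step is a 3.6-fold higher number from compound 1 to compound 2 (0.55 log units; beyond the scatter). Compound 3 `COc1ccc(Cn2c(CCc3c[nH]c4ccccc34)nnc2[C@H](NC(=O)c2cnccn2)c2c[nH]c3ccccc23)c(OC)c1` gives 18.5 nM in this assay, the lowest number among the three measured; how the core of compound 3 differs from the core of compound 1 is not broken down here. Compound 4 `COc1ccc(Cn2c(CCc3ccccc3)nnc2[C@H](NC(=O)c2cnccn2)c2c[nH]c3ccccc23)c(OC)c1` is not yet measured; it differs from compound 3 by phenyl in place of 1H-indol-3-yl on a saturated chain carbon, two bonds along the chain from an aromatic carbon, the same change as made from compound 1 to compound 2, at the same place. Within the data shown here, the expected step is a 3.6-fold higher number from compound 3 to compound 4 (0.56 log units; beyond the scatter), resting on the single earlier step of a 3.6-fold higher number from compound 1 to compound 2 (0.55 log units; beyond the scatter) in this assay. Compound 4 is therefore expected to give about 67 nM, likely between 30 nM and 160 nM.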

Compound 4, half-maximal inhibitory concentration: 5 nM
Estimate against measurement, compound 4: 13-fold (1.13 log units) above; measured number below the stated range.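

In this assay the change from 1H-indol-3-yl to phenyl gives a 3.7-fold lower number from compound 3 to compound 4 (0.57 log units; beyond the scatter), so its direction is not the same on the two cores: the same change on two cores in this assay, a 3.6-fold higher number (0.55 log units; beyond the scatter) from compound 1 to compound 2 and a 3.7-fold lower number (0.57 log units; beyond the scatter) from compound 3 to compound 4, 13-fold (1.12 log units) apart, beyond the scatter of two such steps

The step seen on one core therefore cannot be carried to the other as a fixed increment. Among these compounds, this does not show which part of the core sets the direction, as the core of compound 1 and the core of compound 3 differ in more than one place and each core gives only one pair.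

As far as these compounds go, it remains open whether a core carrying only one of those differences would follow compound 1 or compound 3. Also open, from the compounds shown here alone, is how an amine or a carboxylic acid in place of phenyl, or a longer chain, would behave on either core.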